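The compounds below may be only part of what the source reports. "The series", "measured", "known", "first", "only" and "open" are said of these compounds alone.

Compound 1 `C=CCCCCOc1ccc(C)cc1-c1cnc(OCCC=C)n1C`: 59000 nM
Compound 2 `C=CCCCCOc1cc2ccccc2cc1-c1cnc(OCCC=C)n1C`: 21000 nM

In a functional assay on A549 cells (Homo sapiens) for inhibition, read by colorimetric assay and MTT assay, with a stated time of 72 h (a higher number here means a weaker inhibitor, a lower number a stronger inhibitor), compound 2 gives 21000 nM, the lower of the two numbers, and its gap to compound 1 lies beyond the usual scatter.

Compound 3 `C=CCCCCOc1cc2ccccc2cc1-c1cnc(OCCCCC=C)n1C` keeps everything in compound 2 except one chain: but-3-en-1-yl in place of vinyl on a saturated chain carbon, two bonds along the chain from an oxygen on an aromatic ring. Put simply, but-3-en-1-yl stands in place of vinyl on a saturated chain carbon, two bonds along the chain from an oxygen on an aromatic ring. This turns (but-3-en-1-yl)oxy into (hex-5-en-1-yl)oxy. Within the data shown here, no measured pair shows this change, which leaves the expectation uncertain. In this assay a small move toward a lower number is expected, possibly none beyond the scatter. The estimated change is a 1.3-fold lower number from compound 2 to compound 3 (0.12 log units; within the scatter). For compound 3 the expected value is 16000 nM, within an estimated range of 6000 nM to 40000 nM.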

Compound 3, half-maximal inhibitory concentration: 16000 nM
Compound 3: middle estimate and measured number agree at the digits printed, within the range that was stated.
By their numbers in this assay, from the lowest: compounds 3 and 2 (each within the scatter of the next); then compound 1.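

Among these compounds, compound 3 gives the first reading at this position, on a saturated chain carbon two bonds along the chain from an oxygen on an aromatic ring. In this assay, putting but-3-en-1-yl in place of vinyl, which turns (but-3-en-1-yl)oxy into (hex-5-en-1-yl)oxy, gives a step that does not separate the two compounds (a 1.3-fold lower number from compound 2 to compound 3 (0.12 log units; within the scatter)), so this chain can carry the added length without a clear shift in the number. Nothing measured here explains this result.

The compounds shown leave open whether a still longer chain, or an amine or a carboxylic acid at the end of this chain, would give a step beyond the scatter. They also leave open what the same change would do on the other chain, which is identical in compound 2 and compound 3.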